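A few compounds are considered here, and "the series" means these few. Any claim that something is new, unique, unknown or untested is made for them only; others in the source may bear on it.

Working notes on the series. Of the compounds shown here, three have been measured in an assay on isolated protein for inhibition of aldehyde dehydrogenase 1A1 (Homo sapiens), read by spectrophotometry, tested at 10 uM; a lower number here means less inhibition, a higher number more inhibition at the concentration tested (going by the name of the read-out). Compound 1 `Cc1cccc(Cn2c(CN3CCN(C(=O)C4CCCC4)CC3)nc3ccccc32)c1` gives 67.5%. Compound 2 `Cc1ccc(Cn2c(CN3CCN(C(=O)C4CC4)CC3)nc3ccccc32)cc1` gives 51.5%. Compound 3 `O=C(C1CC1)N1CCN(Cc2nc3ccccc3n2Cc2ccc(F)cc2)CC1` gives 32.7%, the lowest of the three numbers; the nearest to it is compound 2, and the furthest is compound 1. Compound 1 and compound 2 differ in more than one place, so only their two values are noted. Going by the values given here, the single one-place step known is a number 18.8 percentage points lower from compound 2 to compound 3 (beyond the scatter).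

Compound 4 `O=C(C1CC1)N1CCN(Cc2nc3ccccc3n2CC2CC2)CC1` has not yet been measured in this assay. It differs from compound 3 as follows: cyclopropyl in place of 4-fluorophenyl on a saturated chain carbon bound to an aromatic nitrogen. This is a different kind of change from the measured step, which altered a substituent on the aromatic ring while the ring itself was kept; here the whole 4-fluorophenyl leaves and cyclopropyl enters. Among the compounds with values here, no measured step therefore bears directly on it, and the direction can only be guessed from the fact that compound 3 already stands lowest and the change removes the ring that carried the only varied substituent. The working expectation is a further fall in this assay beyond the scatter, estimated at a number 14.7 percentage points lower from compound 3 to compound 4 (beyond the scatter). Compound 4 is accordingly expected to give about 18%, within a range of 4% to 38%.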

Compound 4, a percentage reported as inhibition, at one concentration (the size of the read-out at that concentration, not a potency): 21.2%
The estimate for compound 4 lay 3.2 percentage points below the measured number, within the range that was stated.
By their numbers in this assay, from the lowest: compound 4; then compound 3; then compound 2; then compound 1.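

At the place on a saturated chain carbon bound to an aromatic nitrogen, the series now shows a change of the whole group rather than of a substituent on its aromatic ring: in this assay, 4-fluorobenzyl to cyclopropylmethyl gives a number 11.5 percentage points lower from compound 3 to compound 4 (beyond the scatter), and the comparison with the 4-methylphenyl group gives a number 30.3 percentage points lower from compound 2 to compound 4 (beyond the scatter). Among these three compounds, the two with an aromatic ring at this place stand above compound 4, yet compound 4 still gives 21.2%, so the number falls without reaching zero once the aromatic ring has gone. No measured evidence is available to explain this fall.

The compounds shown cannot separate the loss of the aromatic ring from the drop in heavy atoms, and a plain phenyl, a cyclohexyl or a longer alkyl chain at this place would be needed to tell the two apart. Also open, as far as these compounds go, is how the cyclopentyl group of compound 1 would read when combined with cyclopropylmethyl, since compound 1 differs from compound 4 in more than one place.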